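A few compounds are considered here, and "the series" means these few. Any claim that something is new, unique, unknown or untested is made for them only; others in the source may bear on it.

Working notes on the series.

Compound 1 `C/C(=N\NC(=S)N1CCNCC1)c1ccc(Cl)cc1` is the reference point. In a functional assay on HBL-100 cells (Homo sapiens) for antiproliferative activity, read by MTT assay, with a stated time of 72 h (a higher number here means a weaker inhibitor, a lower number a stronger inhibitor), compound 1 gives 260 nM. Compound 2 `C/C(=N\NC(=S)N1CCNCC1)c1ccc(O)cc1` differs from it in one place: hydroxy in place of chloro on an aromatic carbon. This change gives a 2.1-fold higher number from compound 1 to compound 2 (0.32 log units; beyond the scatter), so in this assay compound 2 gives 540 nM.

Compound 3 `S=C(N/N=C/c1ccc(Cl)cc1)N1CCNCC1` carries the same chloro group on the aromatic ring but sits on a different core; the difference between the two cores is not broken down here. In this assay compound 3 gives 1600 nM, the highest number of the three measured compounds, a step beyond the scatter from both compound 1 and compound 2.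

Compound 4 `Oc1ccc(/C=N/NC(=S)N2CCNCC2)cc1` has not yet been measured. It stands to compound 3 as compound 2 stands to compound 1: hydroxy in place of chloro on an aromatic carbon. The place of the change reads the same in both pairs, so this is the same change on a second core. Among the compounds with values here, the only precedent for it is the step from compound 1 to compound 2, which was modest and beyond the scatter.

On that basis the expectation for this assay is that compound 4 shows a step of about a 2.1-fold higher number from compound 3 to compound 4 (0.33 log units; beyond the scatter), a number of the same kind as a 2.1-fold higher number from compound 1 to compound 2 (0.32 log units; beyond the scatter), because compound 3 starts from 1600 nM. The estimate for compound 4 is therefore 3400 nM, with a likely range from 1700 nM to 7000 nM. The range is wide because the transfer rests on a single measured step, a 2.1-fold higher number from compound 1 to compound 2 (0.32 log units; beyond the scatter), and the core of compound 3 is itself a separate change from that of compound 1.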

Compound 4, half-maximal inhibitory concentration: 180 nM
Compound 4: middle estimate off by 19-fold (1.28 log units), on the high side; measured number below the stated range.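

In this assay, hydroxy in place of chloro on an aromatic carbon gives an 8.9-fold lower number from compound 3 to compound 4 (0.95 log units; beyond the scatter), so the step runs in the opposite direction to the one seen on the core of compound 1, and the two steps do not match: the same change on two cores in this assay, a 2.1-fold higher number (0.32 log units; beyond the scatter) from compound 1 to compound 2 and an 8.9-fold lower number (0.95 log units; beyond the scatter) from compound 3 to compound 4, 18-fold (1.27 log units) apart, beyond the scatter of two such steps

This shows that, in this series, the direction and size of the step depend on the core carrying the change, and that a step measured on one core is a poor guide to the step on the other. It does not show what in the cores produces the difference, since each core contributes only one pair and nothing shown separates the features that distinguish them. Nor does it show which of the two steps is the more typical, or what the same change would do on a third core.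

The compounds shown leave open whether other groups at the same place on the aromatic ring, such as methoxy, fluoro, an amine or a carboxylic acid, would also behave differently on the two cores. Going by these compounds, it also remains open whether the split seen for chloro and hydroxy is particular to this pair of groups or extends across a wider set.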